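The compounds below may be only part of what the source reports. "The series", "measured", "known", "first", "only" and "open" are said of these compounds alone.

Among the measured compounds shown here, in a functional assay on 786-0 cells (Homo sapiens) for inhibition, read by sulforhodamine B assay, with a stated time of 48 h (on this read-out higher numbers stand for weaker inhibition of growth and lower numbers for stronger inhibition of growth), compound 1 `CC1(/C=C/c2ccccc2)C=CC(=O)O1` gives 170000 nM, the higher of the two numbers so far. Compound 2 `CC1(/C=C/c2ccccc2C(F)(F)F)C=CC(=O)O1` gives 27900 nM. For the measured compounds named here, the one measured step, a 6.1-fold lower number from compound 1 to compound 2 (0.78 log units; beyond the scatter), is modest and beyond the scatter, and it comes with trifluoromethyl in place of hydrogen on an aromatic carbon. Compound 3 `CC1(/C=C/c2cccc(O)c2)C=CC(=O)O1` carries a different change on the core of compound 1: hydroxy in place of hydrogen on an aromatic carbon. Going by the values given here, no hydroxy compound has been measured, so that single step bears on this change only loosely. A smaller step in the same direction, toward a lower number, is expected, although a step within the scatter remains possible. The expected step is a 2.3-fold lower number from compound 1 to compound 3 (0.36 log units; beyond the scatter). For compound 3 the estimated value is 75000 nM, with an expected range from 25000 nM to 200000 nM.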

Compound 3, concentration for total growth inhibition: 196000 nM
Compound 3: middle estimate off by 2.6-fold (0.42 log units), on the low side, and the stated range covers the measured number.
By their numbers in this assay, from the lowest: compound 2; then compounds 1 and 3 (each within the scatter of the next).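

In this assay, hydroxy in place of hydrogen on an aromatic carbon, meta to a group of 9 heavy atoms, gives a 1.2-fold higher number from compound 1 to compound 3 (0.06 log units; within the scatter) and so leaves the number where it stood. A substitution on this aromatic ring therefore does not by itself shift the number: trifluoromethyl in place of hydrogen gives a 6.1-fold lower number from compound 1 to compound 2 (0.78 log units; beyond the scatter) as a step beyond the scatter, and the hydroxy step stays within it. Nothing measured in this series speaks to why the two steps differ.

Open, going by these compounds, is whether hydroxy elsewhere on the ring, or trifluoromethyl at this same place, would give a different step. Also open, on these data alone, is whether an amine, a carboxylic acid or a methoxy group at this place would move the number beyond the scatter.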